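Trifluoromethyl in place of methoxy: starting from a limit

The source may hold more compounds than are shown below. What is called first, only, known or untested is meant among the compounds shown, and "the series" means these compounds.

Compound 1, `CSc1ccccc1NC(=O)N[C@H]1CC[C@H](Oc2ccc(F)cc2)CC1`, in a functional assay on CRL2813 cells (Homo sapiens) for cytotoxicity, read by sulforhodamine B assay, with a stated time of 5 days; on this read-out lower numbers stand for stronger inhibition and higher numbers for weaker inhibition: > 20000 nM, which is a limit of the assay.
Compound 2, `COc1ccccc1NC(=O)N[C@H]1CC[C@H](Oc2ccc(F)cc2)CC1`, in this assay: > 20000 nM, again a limit of the assay.

Compound 2 therefore stands at the limit of this assay, with no number of its own. Among the measured compounds shown here, the one measured step, a step that the two limits leave unreadable from compound 1 to compound 2, is unreadable because both of its ends sit at the limit (the limit of > 20000 nM in this assay, at which 2 of the 2 values shown sit). Compound 3, `O=C(Nc1ccccc1C(F)(F)F)N[C@H]1CC[C@H](Oc2ccc(F)cc2)CC1`, differs from compound 2 by trifluoromethyl in place of methoxy on an aromatic carbon. No measured step can be read for its size, so nothing shown points to a step beyond the scatter in either direction in this assay, and the likeliest outcome is that compound 3 again returns only the limit. Compound 3 is accordingly expected near 25000 nM, in a range from 8000 nM to 80000 nM. The expected step that the limit leaves unreadable from compound 2 to compound 3 is thus set at essentially nothing.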

Compound 3, half-maximal inhibitory concentration: > 20000 nM
Compound 3 ended at the assay's limit (the forecaster's own chance of this, stated with the estimate: 80%); the middle value is on the limit's open side.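

Among the compounds shown here, no step among compound 1, compound 2 and compound 3 can be read, because each value is only a limit: the limit of > 20000 nM in this assay, at which 3 of the 3 values shown sit.

The compounds shown leave open whether methylsulfanyl, methoxy and trifluoromethyl differ at all in this assay once a value falls inside the measurable range.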